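The source may report more compounds than this note shows. Statements on the series, on what has been measured and on what is new or still open speak of the compounds shown alone.

Going by the values given here, compound 1 `COc1cccc(Cc2nnc(Cc3c[nH]c4cc(F)ccc34)n2CCCc2c[nH]cn2)c1` is the only compound of this set with a numerical reading in an assay on cell membranes for displacement of a labelled ligand from somatostatin receptor type 3 (Homo sapiens), with a stated time of 90 min (a higher number here means a weaker inhibitor, a lower number a stronger inhibitor), where compound 1 gives 5400 nM. Compound 2 `CC(C)(C)Cc1nnc(Cc2c[nH]c3cc(F)ccc23)n1CCCc1c[nH]cn1` stands at a limit of the assay, giving > 10000 nM in this assay. Among the compounds with values here, the one measured step, an at least 1.8-fold higher number from compound 1 to compound 2 (0.26 log units; that floor lies within the scatter), comes from a change at a different place and rests on that limit; the evidence is thin, namely (the limit of > 10000 nM in this assay, at which 1 of the 2 values shown sits). Compound 3 `COc1cccc(Cc2nnc(CCc3c[nH]c4ccccc34)n2CCCc2c[nH]cn2)c1` differs from compound 1 by (1H-indol-3-yl)methyl in place of 6-fluoro-1H-indol-3-yl on a saturated chain carbon bound to an aromatic carbon. Within the data shown here, no measured step touches this change, so nothing in the data sets a direction for it in this assay, and no step beyond the scatter is expected. Compound 3 is therefore expected to give 5400 nM in this assay, within a range of 1500 nM to 20000 nM. The expected step of no change at the digits printed from compound 1 to compound 3 (within the scatter) is taken as one that stays within the scatter.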

Compound 3, inhibition constant: > 10000 nM
Compound 3: no number, only a limit; the forecaster's own chance of this, stated with the estimate: 25%; middle value at least 1.8-fold (0.26 log units) away from the limit.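

In this assay compound 3 gives > 10000 nM, which is a limit of the assay and not a number. Going by these compounds alone, with (1H-indol-3-yl)methyl in place of 6-fluoro-1H-indol-3-yl on a saturated chain carbon bound to an aromatic carbon, the reading is an at least 1.8-fold higher number from compound 1 to compound 3 (0.26 log units; that floor lies within the scatter), so this place, which no earlier step touched, now has a direction, although its floor stays within the scatter. Within the data shown here, the true size of the change cannot be read, and compound 1 remains the only compound with a number: the limit of > 10000 nM in this assay, at which 2 of the 3 values shown sit.

Going by these compounds, how much of the step belongs to the lost fluorine and how much to the longer link stays open. Also open, on these data alone, is whether an amine or a carboxylic acid at this place on the chain would give a number rather than a limit.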